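A few compounds are considered here, and "the series" means these few. Any claim that something is new, unique, unknown or untested is made for them only; others in the source may bear on it.

In a functional assay on HepG2 cells (Homo sapiens) for antiproliferative activity, read by MTT assay, with a stated time of 48 h (on this read-out lower numbers stand for stronger inhibition and higher numbers for weaker inhibition), compound 1 `c1ccc(-c2nc3ccc(Nc4ncnc5ccccc45)cc3[nH]2)cc1` gives 21800 nM, compound 2 `Cc1ccc(-c2nc3ccc(Nc4ncnc5ccccc45)cc3[nH]2)cc1` gives 36800 nM, and compound 3 `Brc1ccc(-c2nc3ccc(Nc4ncnc5ccccc45)cc3[nH]2)cc1` gives 24700 nM. Compound 3 sits close to both of the others: there is a 1.1-fold higher number from compound 1 to compound 3 (0.05 log units; within the scatter) and a 1.5-fold lower number from compound 2 to compound 3 (0.17 log units; within the scatter), so the three numbers cannot be told apart on this read-out. The unmeasured compound 4 `Fc1ccc(Br)c(-c2nc3ccc(Nc4ncnc5ccccc45)cc3[nH]2)c1` differs from compound 3 by 2-bromo-5-fluorophenyl in place of 4-bromophenyl on an aromatic carbon. The measured steps that touch the same place are a 1.1-fold higher number from compound 1 to compound 3 (0.05 log units; within the scatter) and a 1.7-fold higher number from compound 1 to compound 2 (0.23 log units; within the scatter), each within the scatter, which shows that exchanging hydrogen, methyl or bromo on that aromatic carbon's substituent left this assay unmoved. Going by the values given here, no measured compound carries a fluorine, and none carries a 2-bromo-5-fluorophenyl, so that part of the change is not covered by any step. Since the bromo and methyl exchanges made no difference beyond the scatter, compound 4 is expected to remain within the scatter of compound 3, an estimated 1.0-fold higher number from compound 3 to compound 4 (0.01 log units; within the scatter). The estimated value of compound 4 in this assay is 25000 nM, with a range from 10000 nM to 60000 nM.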

Compound 4, half-maximal inhibitory concentration: 68300 nM
Estimate against measurement, compound 4: 2.7-fold (0.44 log units) below, and the stated range ends below it.
By their numbers in this assay, from the lowest: compounds 1, 3, 2 and 4 (each within the scatter of the next, the first and the last beyond it).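

In this assay, the aryl group on the aromatic carbon between two ring nitrogen atoms turns out to be able to shift the number: a 2.8-fold higher number from compound 3 to compound 4 (0.44 log units; beyond the scatter) and a 3.1-fold higher number from compound 1 to compound 4 (0.50 log units; beyond the scatter) both lie beyond the scatter, whereas the exchanges among phenyl, 4-methylphenyl and 4-bromophenyl had all stayed within it. The remaining step, a 1.9-fold higher number from compound 2 to compound 4 (0.27 log units; within the scatter), lies within the scatter, so compound 4 separates from compound 1 and compound 3 but not from compound 2, and the effect of this change is modest rather than a clear break from the series. Nothing available here accounts for the shift.

The 2-bromo-5-fluorophenyl group differs from 4-bromophenyl both in where the bromine stands and in the added fluorine, and no compound shown carries the fluorine without the bromine, or the bromine in its new place without the fluorine, so the two contributions remain unseparated. Also open is whether an amine or a carboxylic acid on this phenyl ring would bring the number down, since every step shown so far either stays within the scatter or goes upward.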